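Shortening the alkyl chain: from compound 3 to compound 4

A few compounds are considered here, and "the series" means these few. Any claim that something is new, unique, unknown or untested is made for them only; others in the source may bear on it.

Measured in an ADME assay on SK-OV-3 cells (Homo sapiens) for cytotoxicity, read by sulforhodamine B assay, with a stated time of 48 h, tested at 10 uM; a higher number here means more inhibition at the concentration tested (going by the name of the read-out), a lower number less inhibition:
Compound 1, `CCCCc1cn(C(c2ccccc2)c2cc3cc(Br)ccc3nc2OC)nn1`, gives 11.1%
Compound 2, `CCCCCCCc1cn(C(c2ccccc2)c2cc3cc(Br)ccc3nc2OC)nn1`, gives 10.5%
Compound 3, `CCCCCCCCc1cn(C(c2ccccc2)c2cc3cc(Br)ccc3nc2OC)nn1`, gives 2.06%

Among these three, compound 3 has the lowest number in this assay, yet its gap to compound 2 and its gap to compound 1 both lie within the scatter, so no real order among them can be claimed. Compound 4, `CCCCCc1cn(C(c2ccccc2)c2cc3cc(Br)ccc3nc2OC)nn1`, is obtained from compound 3 by the change (hydrogen in place of propyl on a saturated chain carbon, five bonds along the chain from an aromatic carbon). For the measured compounds named here, three measured steps bear on this, all of them changes in the length of the same chain: a number 0.6 percentage points lower from compound 1 to compound 2 (within the scatter), a number 9 percentage points lower from compound 1 to compound 3 (within the scatter) and a number 8.4 percentage points lower from compound 2 to compound 3 (within the scatter). None of these chain-lengthening steps moved the number beyond the scatter, and the reverse move to a shorter chain is therefore expected to do no more. For compound 4 the step of a number 5.9 percentage points higher from compound 3 to compound 4 (within the scatter) is expected to stay within the scatter. Compound 4 is thus estimated at 8%, in the range 0% to 18%.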

Compound 4, a percentage reported as inhibition, at one concentration (the size of the read-out at that concentration, not a potency): 10.5%
Compound 4: middle estimate off by 2.5 percentage points, on the low side; low and high end bracket the measured number.
By their numbers in this assay, from the lowest: compounds 3, 2, 4 and 1 (each within the scatter of the next).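

In this assay, shortening the chain by removing propyl gives a number 8.4 percentage points higher from compound 3 to compound 4 (within the scatter), while the comparisons with the other two chains give no change at the digits printed from compound 2 to compound 4 (within the scatter) and a number 0.6 percentage points lower from compound 1 to compound 4 (within the scatter). Compound 4 thus adds a fourth chain length at this position, and none of the four compounds stands apart from the others in this assay. It also allows the same chain change to be compared in two different pairs of compounds, and both comparisons agree within the scatter: the same change on two cores in this assay, a number 0.6 percentage points lower (within the scatter) from compound 1 to compound 2 and a number 8.4 percentage points lower (within the scatter) from compound 4 to compound 3, 7.8 percentage points apart, within the scatter of two such steps; the second pair of steps reads the same way: the same change on two cores in this assay, a number 8.4 percentage points lower (within the scatter) from compound 2 to compound 3 and a number 0.6 percentage points lower (within the scatter) from compound 1 to compound 4, 7.8 percentage points apart, within the scatter of two such steps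

Going by these compounds, all four compounds carry a plain alkyl chain on the shared core, so it remains open whether an amine or a carboxylic acid on that chain, or a much longer chain, would move the number beyond the scatter. A reading at a single concentration also leaves open how these compounds would compare across a range of concentrations.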